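The source may report more compounds than this note shows. Statements on the series, on what has been measured and on what is new or still open speak of the compounds shown alone.

In a functional assay on HepG2 cells (Homo sapiens) for antiproliferative activity, read by CCK-8 assay, with a stated time of 48 h (on this read-out lower numbers stand for stronger inhibition and higher numbers for weaker inhibition), compound 1 `COc1ccc(/C=C\c2cc(OC)c(OC)c(OC)c2)cc1OCc1ccc(C=O)cc1` gives 800 nM. Compound 2 `COc1ccc(/C=C\c2cc(OC)c(OC)c(OC)c2)cc1OCc1ccc(CN2CCCC[C@@H]2C(=O)O)cc1` reads > 10000 nM, which is a limit of the assay and not a number. Compound 3 `COc1ccc(/C=C\c2cc(OC)c(OC)c(OC)c2)cc1OCc1ccc(CO)cc1` differs from compound 2 by hydroxy in place of 2-carboxypiperidin-1-yl on a saturated chain carbon bound to an aromatic carbon, which cut one bond further out reads (2-carboxypiperidin-1-yl)methyl to hydroxymethyl. Among the compounds with values here, the one measured step that bears on this change is an at least 12-fold higher number from compound 1 to compound 2 (1.09 log units; beyond the scatter), and it brings in the group now leaving. A large fall in this assay is therefore expected, of a size left open by the limit. The expected change is an at least 10-fold lower number from compound 2 to compound 3 (1.00 log units; beyond the scatter). For compound 3 the estimate is 1000 nM, with an expected range of 300 nM to 4000 nM.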

Compound 3, half-maximal inhibitory concentration: 2400 nM
Beside the measured number, compound 3's estimate is 2.4-fold (0.38 log units) below it, within the range that was stated.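

In this assay, replacing formyl on the aromatic carbon does not always cost as much as (2-carboxypiperidin-1-yl)methyl did: hydroxymethyl gives a 3.0-fold higher number from compound 1 to compound 3 (0.48 log units; beyond the scatter). Going by these compounds, removing 2-carboxypiperidin-1-yl from the saturated chain carbon in favour of hydroxy gives an at least 4.1-fold lower number from compound 2 to compound 3 (0.61 log units; beyond the scatter), so part of the loss is recovered, though the true size of this step stays open. Compound 2 stands at a limit and not a number: the limit of > 10000 nM in this assay, at which 1 of the 3 values shown sits.

Still open, on these data alone, is whether a plain amine such as piperidin-1-ylmethyl would read like compound 3. It is also unclear whether the carboxylic acid or the piperidine ring carries the loss in compound 2.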